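Swapping isopropyl for 4-fluorophenyl on a weakly cytotoxic core

A few compounds are considered here, and "the series" means these few. Any claim that something is new, unique, unknown or untested is made for them only; others in the source may bear on it.

Compound 1 `Cc1cc(NC(C)C)nc(SCc2nc3ccccc3[nH]2)n1` carries an isopropylamino group on the shared core. In a functional assay on ECa-109 cells (Homo sapiens) for cytotoxicity, read by MTT assay, with a stated time of 72 h (on this read-out higher numbers stand for weaker inhibition and lower numbers for stronger inhibition), compound 1 gives only a limit, > 100000 nM. Compound 2 `Cc1cc(N2CCCCC2)nc(SCc2nc3ccccc3[nH]2)n1` likewise gives only a limit in this assay, > 100000 nM. Compound 3 `Cc1ccc(Nc2cc(C)nc(SCc3nc4ccccc4[nH]3)n2)cc1` gives a measurable 57300 nM in this assay. Two of the three values sit at the limit of > 100000 nM in this assay, at which 2 of the 3 values shown sit, so the step from compound 1 to compound 2 is a step that the two limits leave unreadable from compound 1 to compound 2, while the step from compound 1 to compound 3 is an at least 1.7-fold lower number from compound 1 to compound 3 (0.24 log units; that floor lies within the scatter). Compound 4 `Cc1cc(Nc2ccc(F)cc2)nc(SCc2nc3ccccc3[nH]2)n1` differs from compound 1 by 4-fluorophenyl in place of isopropyl on a nitrogen on an aromatic ring. The nearest measured change, 4-methylphenyl in place of isopropyl, gave an at least 1.7-fold lower number from compound 1 to compound 3 (0.24 log units; that floor lies within the scatter), so a small lowering, or none beyond the scatter, is expected. Compound 4 is therefore estimated at 60000 nM, between 25000 nM and 150000 nM, an expected step of an at least 1.6-fold lower number from compound 1 to compound 4 (0.22 log units; that floor lies within the scatter).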

Compound 4, half-maximal inhibitory concentration: 69500 nM
Estimate against measurement, compound 4: 1.2-fold (0.06 log units) below; low and high end bracket the measured number.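

On this nitrogen, fluoro and methyl on the aromatic ring cannot be told apart in this assay, with a 1.2-fold higher number from compound 3 to compound 4 (0.08 log units; within the scatter). Against the isopropylamino and piperidin-1-yl groups, (4-fluorophenyl)amino gives an at least 1.4-fold lower number from compound 1 to compound 4 (0.15 log units; that floor lies within the scatter) and an at least 1.4-fold lower number from compound 2 to compound 4 (0.15 log units; that floor lies within the scatter). These two steps are only floors because the values of compound 1 and compound 2 are limits: the limit of > 100000 nM in this assay, at which 2 of the 4 values shown sit.

On these data alone, whether an aromatic ring on this nitrogen truly lowers the number beyond the scatter stays open. So does the outcome with other groups in place of the fluoro, such as methoxy or a carboxylic acid.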